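Aryl exchange on compound 3, a series at its limit

A few compounds are considered here, and "the series" means these few. Any claim that something is new, unique, unknown or untested is made for them only; others in the source may bear on it.

Compound 3 (`COc1cc(NC(=O)n2cc(-c3ccc(O)cc3)n(-c3cc(OC)c(OC)c(OC)c3)c2=O)cc(OC)c1OC`) reads > 50000 nM in a functional assay on K-562R cells (Homo sapiens) for cytotoxicity, read by MTT assay, with a stated time of 48 h (a lower number here means a stronger inhibitor, a higher number a weaker inhibitor), and this is a limit of the assay, not a number. Compound 1 (`COc1cc(-n2c(-c3ccc(O)cc3)c[nH]c2=O)cc(OC)c1OC`) reads > 50000 nM and this too is a limit. Compound 2 (`COc1ccc(-c2c[nH]c(=O)n2-c2cc(OC)c(OC)c(OC)c2)cc1`) reads > 50000 nM and this is again a limit. Going by the values given here, the series so far shows the limit of > 50000 nM in this assay, at which 3 of the 3 values shown sit, and so offers no numerical starting point.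

Compound 4 (`COc1ccc(-c2cn(C(=O)Nc3cc(OC)c(OC)c(OC)c3)c(=O)n2-c2cc(OC)c(OC)c(OC)c2)cc1N`) carries 3-amino-4-methoxyphenyl in place of the 4-hydroxyphenyl of compound 3, on an aromatic carbon of the five-membered ring (3-amino-4-methoxyphenyl in place of 4-hydroxyphenyl on an aromatic carbon). Among the compounds with values here, only one measured step bears on this exchange: a step that the two limits leave unreadable from compound 1 to compound 2 with methyl in place of hydrogen on an oxygen on an aromatic ring. Within the data shown here, it covers the methoxy part of the new group, and no measured step covers the amino part.

Compound 2 at > 50000 nM gives no sign that the methoxy alone brings a readable gain. A further reading at the limit is therefore slightly favoured, and any change is expected only toward a stronger inhibitor. The estimated at least 2.0-fold lower number from compound 3 to compound 4 (0.30 log units; that floor lies within the scatter) is uncertain in size and rests on very little. The expected value for compound 4 is 25000 nM with an estimated range from 2000 nM to 50000 nM in this assay.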

Compound 4, half-maximal inhibitory concentration: 9400 nM
For compound 4 the middle estimate is 2.7-fold (0.42 log units) above the measured one, within the range that was stated.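

In this assay, going by these compounds alone, the exchange of 4-hydroxyphenyl for 3-amino-4-methoxyphenyl, on an aromatic carbon of the five-membered ring, gives the first readable step, an at least 5.3-fold lower number from compound 3 to compound 4 (0.72 log units; beyond the scatter), and its size is only a floor, so this position can move the read-out on the core of compound 3. Compound 3 gives > 50000 nM, which is a limit and not a number. Within the data shown here, the step between compound 1 and compound 2 cannot be read, which leaves the exchange above as the only readable information on this position, and compound 4 as the only compound off the limit: the limit of > 50000 nM in this assay, at which 3 of the 4 values shown sit.

The new group differs from the old one in two parts, and the compounds shown do not separate the amino group from the methoxy group on the core of compound 3, so which of them carries the step stays open. A plain 4-methoxyphenyl at this place, or a 4-methoxyphenyl with a hydroxyl, an acetamide or a dimethylamino group in place of the amino group, would divide the step between the two parts and show whether the amine itself is needed.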